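The source may hold more compounds than are shown below. What is called first, only, known or untested is meant among the compounds shown, and "the series" means these compounds.

Of the compounds shown here, three carrying a shared core have been measured in a functional assay on MCF7 cells (Homo sapiens) for antiproliferative activity, read by MTT assay, with a stated time of 72 h; a higher number here means a weaker inhibitor, a lower number a stronger inhibitor. Compound 1 `CCN1CCN(c2cc(C)c3cc(NC(=O)c4cc(Cl)cc(Cl)c4)ccc3n2)CC1` gives 6090 nM, compound 2 `CCN1CCN(c2cc(C)c3cc(NC(=O)c4ccco4)ccc3n2)CC1` gives 41200 nM, and compound 3 `CCN1CCN(c2cc(C)c3cc(NC(=O)c4cc5ccccc5[nH]4)ccc3n2)CC1` gives 2950 nM. Among these, compound 3 has the lowest number: exchanging the 3,5-dichlorophenyl for a furan-2-yl gave a 6.8-fold higher number from compound 1 to compound 2 (0.83 log units; beyond the scatter), exchanging it for a 1H-indol-2-yl gave a 2.1-fold lower number from compound 1 to compound 3 (0.31 log units; beyond the scatter), and from the furan to the indole the move was a 14-fold lower number from compound 2 to compound 3 (1.15 log units; beyond the scatter). Compound 4 `CCN1CCN(c2cc(C)c3cc(NC(=O)c4ccc(Br)cc4)ccc3n2)CC1` is the next member to be tested, and it differs from compound 3 in one place: 4-bromophenyl in place of 1H-indol-2-yl on a carbonyl carbon. For the measured compounds named here, the step that bears most on this is the one between compound 1 and compound 3, where a halogenated phenyl stood against the indole and the number fell only modestly; a 4-bromophenyl is closer in kind to that dichlorophenyl than to the furan, so a modest rise in the number, rather than the large swing seen between compound 2 and compound 3, is expected. Compound 4 is therefore estimated at 7000 nM, with a range from 3000 nM to 16000 nM, which would mean a 2.4-fold higher number from compound 3 to compound 4 (0.38 log units; beyond the scatter).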

Compound 4, half-maximal inhibitory concentration: 5940 nM
Compound 4: middle estimate off by 1.2-fold (0.07 log units), on the high side; the measured number falls inside the stated range.
By their numbers in this assay, from the lowest: compounds 3, 4 and 1 (each within the scatter of the next, the first and the last beyond it); then compound 2.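

In this assay, for the compounds shown here, the 4-bromophenyl cannot be told apart from the 1H-indol-2-yl on this carbonyl carbon, with a 2.0-fold higher number from compound 3 to compound 4 (0.30 log units; within the scatter), so a group with no hydrogen-bond donor and only one aromatic ring holds up here as well as the indole, which has one donor and two rings. A single bromine on the phenyl also matches the two chlorines of the 3,5-dichlorophenyl, with a 1.0-fold lower number from compound 1 to compound 4 (0.01 log units; within the scatter), although compound 1 and compound 3 themselves lie just beyond the scatter of each other. The furan-2-yl of compound 2 now stands apart from all three others, again in a 6.9-fold lower number from compound 2 to compound 4 (0.84 log units; beyond the scatter).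

No measurement shown gives a reason for any of these steps. As far as these compounds go, it remains open whether an amine or a carboxylic acid in place of the bromine would keep the number at this level.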